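The source may report more compounds than this note shows. Statements on the series, on what has been measured and on what is new or still open speak of the compounds shown alone.

Compound 1, `O=C(N1CCCN(Cc2ccc(OCc3ccccc3)cc2)CC1)n1cccn1`, gives 450 nM in an assay on membranes from brain for binding affinity to Fatty-acid amide hydrolase 1 (Mus musculus), read by fluorescence, with stated times of 1 h and 30 min; a lower number here means a stronger inhibitor, a higher number a weaker inhibitor. Compound 2, `N#Cc1cnn(C(=O)N2CCCN(Cc3ccc(OCc4ccccc4)cc3)CC2)c1`, bears cyano in place of hydrogen on an aromatic carbon; its result in this assay is a limit of the measurement, < 10 nM, as noted in the limit of < 10 nM in this assay, at which 1 of the 3 values shown sits. That change gave an at least 45-fold lower number from compound 1 to compound 2 (1.65 log units; beyond the scatter). Compound 3, `CN(CCN(C)C(=O)n1cccn1)Cc1ccc(OCc2ccccc2)cc1`, gives 510 nM in this assay; the difference between its core and the core of compound 1 is not broken down here. Compound 4, `CN(CCN(C)C(=O)n1cc(C#N)cn1)Cc1ccc(OCc2ccccc2)cc1`, has not yet been measured and differs from compound 3 by cyano in place of hydrogen on an aromatic carbon, the same change as from compound 1 to compound 2. Set beside that earlier step, the step expected here is a 43-fold lower number from compound 3 to compound 4 (1.63 log units; beyond the scatter), resting on the step of an at least 45-fold lower number from compound 1 to compound 2 (1.65 log units; beyond the scatter). Compound 4 is thus estimated at 12 nM in this assay.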

Compound 4, half-maximal inhibitory concentration: 120 nM
For compound 4 the middle estimate is 10-fold (1.00 log units) below the measured one; measured number outside the range, above it.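

In this assay, cyano in place of hydrogen on an aromatic carbon lowers the number on both cores, with a 4.3-fold lower number from compound 3 to compound 4 (0.63 log units; beyond the scatter), so the direction of the change carries over to the core of compound 3. The size of the step does not hold from one core to the other: the same change on two cores in this assay, an at least 45-fold lower number (1.65 log units; beyond the scatter) from compound 1 to compound 2 and a 4.3-fold lower number (0.63 log units; beyond the scatter) from compound 3 to compound 4, at least 10-fold (1.02 log units) apart, beyond the scatter of two such steps Compound 2 gives < 10 nM, a limit and not a number, and these two pairs alone do not show what sets the size of the step or how it would fall on any further core.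

The compounds shown leave open how a carboxylic acid or an amine in place of cyano would fare at that position. They also leave open how 4-cyano-1H-pyrazol-1-yl would fare on a core with a longer chain than that of compound 3.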